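The compounds below may be only part of what the source reports. "The series", "measured", "known", "first", "only" and "open" are said of these compounds alone.

Compound 1 `CCC1CCCN(C(=O)CN2CN(c3ccccc3)C3(CCN(C(=O)c4ccc(C5CCCCC5)cc4)CC3)C2=O)C1` has the lowest of the three numbers measured in an assay on HEK293 cells for displacement of a labelled ligand from NPC1-like intracellular cholesterol transporter 1 (Homo sapiens); on this read-out higher numbers stand for weaker inhibition and lower numbers for stronger inhibition: in this assay compound 1 gives 2600 nM. Compound 3 `CC(C)(C)c1ccc(C(=O)N2CCC3(CC2)C(=O)N(CC(=O)NCCCN)CN3c2ccccc2)cc1` stands nearest, as in this assay compound 3 gives 4200 nM, a gap within the scatter. Compound 2 `CC(C)(C)c1ccc(C(=O)N2CCC3(CC2)C(=O)N(CC(=O)N2CCCCC2CCO)CN3c2ccccc2)cc1` stands furthest, since in this assay compound 2 gives 6100 nM, a gap beyond the scatter. For the measured compounds named here, the only step between measured compounds that differ in one place is a 1.5-fold lower number from compound 2 to compound 3 (0.16 log units; within the scatter), and it alters the group on the carbonyl carbon rather than a ring carbon.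

Compound 4 `NC(=O)C1CCCN(C(=O)CN2CN(c3ccccc3)C3(CCN(C(=O)c4ccc(C5CCCCC5)cc4)CC3)C2=O)C1` differs from compound 1 in one place: carbamoyl in place of ethyl on a saturated ring carbon. Going by the values given here, no measured step touches this ring carbon, so the data give no direct guide to the size or direction of this change. Among the compounds with values here, the one step that exists, with its hydrogen-bond donors entering, stayed within the scatter. Compound 4 is therefore expected to stay close to compound 1, with the expected step of a 1.2-fold higher number from compound 1 to compound 4 (0.09 log units; within the scatter) lying within the scatter. The estimate for compound 4 in this assay is 3200 nM, in a range from 1200 nM to 9000 nM.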

Compound 4, half-maximal inhibitory concentration: 3100 nM
Estimate against measurement, compound 4: 1.0-fold (0.01 log units) above; the range from low to high includes it.
By their numbers in this assay, from the lowest: compounds 1, 4, 3 and 2 (each within the scatter of the next, the first and the last beyond it).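

On the saturated ring carbon two ring bonds from the ring nitrogen, carbamoyl in place of ethyl gives a 1.2-fold higher number from compound 1 to compound 4 (0.08 log units; within the scatter) in this assay, so a group with a hydrogen-bond donor and acceptor replaces one with neither, and the number stays within the scatter. For the compounds shown here, this is the first step at this ring carbon, as the earlier step changed the group on a carbonyl carbon, and it shows that this single exchange at this position leaves the number in this assay essentially unmoved. Nothing available here bears on why the two compounds read so alike.

From the compounds shown here alone, whether a carboxylic acid, an amine or a longer chain on this ring carbon would also stay within the scatter remains open. Also open, going by these compounds, is whether the same exchange would read alike with tert-butyl in place of cyclohexyl on the benzoyl group's ring.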